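Methyl for hydrogen on the fused ring of compound 1

A few compounds are considered here, and "the series" means these few. Any claim that something is new, unique, unknown or untested is made for them only; others in the source may bear on it.

Going by the values given here, compound 1 `O=c1oc(-c2ccccc2I)nc2ccccc12` stands highest of the two numbers so far in an assay on isolated protein for inhibition of complement C1r subcomponent (Homo sapiens) (a higher number here means a weaker inhibitor, a lower number a stronger inhibitor), at 16700 nM; compound 2 `O=c1oc(-c2ccccc2I)nc2ccc(Cl)cc12`, with chloro in place of hydrogen on an aromatic carbon, gives 7800 nM. Compound 3 `Cc1ccc2c(=O)oc(-c3ccccc3I)nc2c1` carries methyl in place of hydrogen on an aromatic carbon. Among the compounds with values here, the only step that bears on this change is the chloro one, which gave a 2.1-fold lower number from compound 1 to compound 2 (0.33 log units; beyond the scatter); methyl is a different group at a different place, so that step is a loose guide only. A step of similar or smaller size toward a lower number is expected, or none beyond the scatter, so compound 3 is estimated at 12000 nM (range 5000 nM to 30000 nM), which means a 1.4-fold lower number from compound 1 to compound 3 (0.14 log units; within the scatter).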

Compound 3, half-maximal inhibitory concentration: > 62500 nM
Compound 3 was reported as a limit (the forecaster's own chance of this, stated with the estimate: 5%); at least 5.2-fold (0.71 log units) between middle value and limit.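

In this assay, methyl in place of hydrogen on an aromatic carbon gives an at least 3.7-fold higher number from compound 1 to compound 3 (0.57 log units; beyond the scatter), whereas the chloro change, at a different place, gave a 2.1-fold lower number from compound 1 to compound 2 (0.33 log units; beyond the scatter). The shared core therefore does not tolerate every aromatic substitution equally, and the direction of the step can reverse. The reading for compound 3 is a limit of the assay, not a number, so the full size of this step stays unknown: the limit of > 62500 nM in this assay, at which 1 of the 3 values shown sits.

Going by these compounds, whether the rise follows methyl itself or this position stays open. An amine or chloro at this place, and methyl at the chloro place of compound 2, would separate the two.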